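A few compounds are considered here, and "the series" means these few. Any claim that something is new, unique, unknown or untested is made for them only; others in the source may bear on it.

Values so far in a physicochemical assay for lipophilicity, read by HPLC, at pH 7.4; on this read-out lower numbers stand for lower lipophilicity and higher numbers for higher lipophilicity
- compound 1 `CC(=O)NC1C2CC3CC1CC(C2)C31OO[C@]2(CC[C@@H](c3ccc(OCC(=O)O)cc3)CC2)O1` gives 1.8
- compound 2 `O=C(O)c1cccc([C@H]2CC[C@]3(CC2)OOC2(O3)C3CC4CC(C3)CC2C4)c1` gives 3

Compound 2 stands highest of the two numbers, and its gap to compound 1 lies beyond the scatter. Going by the values given here, no measured pair isolates a single change, so the values give no direct guide to the next step.

Next in line is compound 3 `O=C(O)c1cc([C@H]2CC[C@]3(CC2)OOC2(O3)C3CC4CC(C3)CC2C4)ccc1O` which is still unmeasured. It differs from compound 2 by hydroxy in place of hydrogen on an aromatic carbon and the new group stands ortho to a carboxy group and para to a large group.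

With only the structural change to go on, the expectation is loose. The expected step of a number 0.40 log units lower from compound 2 to compound 3 (beyond the scatter) is a modest fall in this assay and a result within the scatter would not surprise. For compound 3 the estimated value is 2.6 (expected range 2 to 3.2).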

Compound 3, distribution coefficient: 3
The estimate for compound 3 lay 0.40 log units below the measured number; the range from low to high includes it.
By their numbers in this assay, from the lowest: compound 1; then compounds 2 and 3 (each within the scatter of the next).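

In this assay, hydroxy in place of hydrogen on an aromatic carbon, ortho to a carboxy group and para to a large group, gives no change at the digits printed from compound 2 to compound 3 (within the scatter). Going by these compounds alone, this is the first pair that isolates a single change, and it shows that this aromatic carbon can carry a hydroxy without a step beyond the scatter on this read-out. The finding rests on this one pair and one position, and no measurement at hand bears on the reason for it.

Still open, going by these compounds, is whether a methoxy or an amine on the same aromatic carbon would read the same way. Also open, on these data alone, is whether the hydroxy would give the same result with a primary amide in place of the carboxy group.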